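Working notes: methylamino in place of aminoamino

The source may report more compounds than this note shows. Statements on the series, on what has been measured and on what is new or still open speak of the compounds shown alone.

compound 1 `N#Cc1c(O)nc(SCc2nc3ccccc3[nH]2)nc1-c1ccccc1`: 6.2 nM
compound 2 `N#Cc1c(NN)nc(SCc2nc3ccccc3[nH]2)nc1-c1ccccc1`: 2.55 nM

Among the measured compounds shown here, in a functional assay on KB cells (Homo sapiens) for cytotoxicity, read by MTT assay, with a stated time of 3 days (on this read-out higher numbers stand for weaker inhibition and lower numbers for stronger inhibition), compound 2 holds the lower of the two numbers so far, at 2.55 nM, and its nearest and only neighbour is compound 1 at 6.2 nM. With just two measurements, this standing says little about the wider series.

The next compound is compound 3 `CNc1nc(SCc2nc3ccccc3[nH]2)nc(-c2ccccc2)c1C#N`. Its difference from compound 2 is methyl in place of amino on a nitrogen on an aromatic ring, so aminoamino becomes methylamino.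

For the measured compounds named here, one measured step bears on this, a 2.4-fold lower number from compound 1 to compound 2 (0.39 log units; beyond the scatter), a modest step that came with aminoamino replacing hydroxy on an aromatic carbon. Going by the values given here, no measured step shows what a methyl does on this nitrogen, so the direction remains tentative. Since aminoamino is altered here, a small upward step in this assay is expected, possibly not beyond the scatter, and no larger than a 2.4-fold lower number from compound 1 to compound 2 (0.39 log units; beyond the scatter) in its most likely form.

The expected change is a 1.6-fold higher number from compound 2 to compound 3 (0.20 log units; within the scatter).

Compound 3 is estimated at 4 nM, with an expected range of 1.3 nM to 12 nM.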

Compound 3, half-maximal inhibitory concentration: 2.7 nM
Estimate against measurement, compound 3: 1.5-fold (0.17 log units) above, and the stated range covers the measured number.
By their numbers in this assay, from the lowest: compounds 2 and 3 (each within the scatter of the next); then compound 1.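

In this assay, methyl in place of amino on a nitrogen on an aromatic ring gives a 1.1-fold higher number from compound 2 to compound 3 (0.02 log units; within the scatter), so this read-out does not separate aminoamino from methylamino, and the terminal amino group of compound 2 shows no measurable contribution here. The earlier comparison covered only hydroxy and aminoamino, whereas exchanging hydroxy for methylamino now gives a 2.3-fold lower number from compound 1 to compound 3 (0.36 log units; beyond the scatter), a modest step close in size to a 2.4-fold lower number from compound 1 to compound 2 (0.39 log units; beyond the scatter), so among these three compounds both nitrogen-linked groups stand apart from hydroxy in the same direction. No supporting measurement is available to explain either the lack of separation or the shift away from hydroxy.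

From the compounds shown here alone, whether this position keeps numbers in the same range with a longer chain on the nitrogen, such as propylamino, or with a second methyl, as in dimethylamino, remains open. Also open, going by these compounds, is how a plain amine or a methoxy group at this aromatic carbon would compare with the hydroxy of compound 1 and the methylamino of compound 3.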